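Swapping a Carbamoyl for an Ethylsulfanyl Chain on the Core

The compounds below may be only part of what the source reports. "The series", "measured", "known", "first", "only" and "open" are said of these compounds alone.

Compound 1 `Nc1nc2ccc(I)cc2s1`: in a functional assay on the whole organism with Rattus norvegicus as the target (on this read-out lower numbers stand for an effect already at smaller amounts and higher numbers for an effect only at larger amounts of compound), compound 1 reaches only the limit > 10 mg/kg.
Compound 2 `Nc1nc2ccc(C3CCCCC3)cc2s1`: in this assay compound 2 likewise reaches only the limit > 10 mg/kg.
Compound 3 `N=c1sc2cc(OC(F)(F)F)ccc2n1CC(N)=O`: in this assay compound 3 gives 7 mg/kg.

Among the measured compounds shown here, compound 3 therefore stands alone: it is the only compound of the three with an actual number, while the other two sit at the limit of > 10 mg/kg in this assay, at which 2 of the 3 values shown sit, and say nothing beyond that. For the measured compounds named here, no pair of measured compounds differs in a single place, so no measured step exists to lean on.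

Compound 4 `CCSCCn1c(=N)sc2cc(OC(F)(F)F)ccc21` differs from compound 3 in one place: (ethylsulfanyl)methyl in place of carbamoyl on a saturated chain carbon bound to an aromatic nitrogen. A hydrogen-bond donor on the carbamoyl leaves and a sulfur-bearing chain enters on the saturated chain carbon bound to the aromatic nitrogen. Going by the values given here, nothing among the measured compounds tells how such a swap plays out in this assay.

The expectation is therefore cautious: compound 4 is estimated at 7 mg/kg, with a range from 2.5 mg/kg to 20 mg/kg. The expected step of no change at the digits printed from compound 3 to compound 4 (within the scatter) is expected to stay within the usual scatter, in no particular direction.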

Compound 4, dose for half-maximal effect: 2.2 mg/kg
Compound 4: middle estimate off by 3.2-fold (0.50 log units), on the high side, outside the stated range (below it).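

The swap of carbamoyl for (ethylsulfanyl)methyl on a saturated chain carbon bound to an aromatic nitrogen gives, in this assay, a 3.2-fold lower number from compound 3 to compound 4 (0.50 log units; beyond the scatter), so this place on the shared core responds to a change of group. The carbamoyl, with its hydrogen-bond donor, can also leave here without any loss of effect on this read-out, and a sulfur-bearing chain is tolerated in its place. Nothing measured here tells why the number falls.

Going by these compounds, it remains open whether the sulfur itself matters or whether the chain alone is enough, a question that a plain butyl chain or an ethoxy-bearing chain in the same place would address. On these data alone, how a carboxylic acid or an amine at the end of this chain would behave also remains open.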